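Adding a Methoxy Group on Two Related Cores

The source may report more compounds than this note shows. Statements on the series, on what has been measured and on what is new or still open speak of the compounds shown alone.

Compound 1 `COc1ccc(/C=C2\S/C(=N\c3csc(-c4ccc(Cl)cc4)c3)NC2=O)cc1` gives 1300 nM in a functional assay on HCT-116 cells (Homo sapiens) for cytotoxicity, read by MTT assay, with a stated time of 72 h; a higher number here means a weaker inhibitor, a lower number a stronger inhibitor. Compound 2 `COc1ccc(/C=C2\S/C(=N\c3csc(-c4ccc(Cl)cc4)c3)NC2=O)cc1OC` carries methoxy in place of hydrogen on an aromatic carbon; in this assay compound 2 gives 1700 nM, which makes a 1.3-fold higher number from compound 1 to compound 2 (0.12 log units; within the scatter). Compound 3 `COc1cccc(N2C(=O)CS/C2=N\c2csc(-c3ccc(Cl)cc3)c2)c1` rests on another core, and the difference between the two cores is not broken down here. In this assay compound 3 reaches only a limit of the assay, > 50000 nM, as recorded by the limit of > 50000 nM in this assay, at which 1 of the 3 values shown sits. Compound 4 `COc1ccc(N2C(=O)CS/C2=N\c2csc(-c3ccc(Cl)cc3)c2)cc1OC` differs from compound 3 by methoxy in place of hydrogen on an aromatic carbon. For the measured compounds named here, this is the same kind of change as the one from compound 1 to compound 2, though the place differs: there the entering methoxy is meta to a large group, here para to a large group. The expected step is a step that the limit leaves unreadable from compound 3 to compound 4, resting on the within-scatter step a 1.3-fold higher number from compound 1 to compound 2 (0.12 log units; within the scatter). Compound 4 is therefore estimated at 60000 nM, most likely again a limit, between 20000 nM and 200000 nM.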

Compound 4, half-maximal inhibitory concentration: 49800 nM
For compound 4 the middle estimate is 1.2-fold (0.08 log units) above the measured one; the measured number falls inside the stated range.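

Set side by side, the same change on the two cores gives only a partial comparison: the same change on two cores in this assay, a 1.3-fold higher number (0.12 log units; within the scatter) from compound 1 to compound 2 and a number no higher (the limit leaves the size open) from compound 3 to compound 4; the limit leaves it open whether they differ

In this assay compound 3 gives > 50000 nM, which is a limit of the assay. The data give a number no higher from compound 3 to compound 4 (the limit leaves the size open) and so these compounds show neither that the methoxy change carries over from one core to the other nor that it fails to.

The compounds shown leave open how the core of compound 3 would respond to a group other than methoxy on the same aromatic carbon, such as a hydroxyl group or an amine. They also leave open whether such a group would give the same result on the core of compound 1.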